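The source may report more compounds than this note shows. Statements on the series, on what has been measured and on what is new or still open speak of the compounds shown alone.

Series built on the shared core of compound 1 `Cc1ccc(N/N=C2\CCC(C)n3c2ncc(C(=O)O)c3=O)cc1`, all read in a functional assay on the whole organism for inhibition, with Rattus norvegicus as the target; on this read-out lower numbers stand for an effect already at smaller amounts and higher numbers for an effect only at larger amounts of compound. In this assay compound 1 gives only a limit of the assay, > 1000 umol/kg. Compound 2 `CC1CC/C(=N\Nc2ccc([N+](=O)[O-])cc2)c2ncc(C(=O)O)c(=O)n21` carries nitro in place of methyl on an aromatic carbon; in this assay compound 2 likewise returns only a limit, > 320 umol/kg. Compound 3 `CCc1ccc(N/N=C2\CCC(C)n3c2ncc(C(=O)O)c3=O)cc1`, with methyl in place of hydrogen on a saturated chain carbon bound to an aromatic carbon relative to compound 1, is the starting point here. In this assay compound 3 also gives only a limit, > 1000 umol/kg. Compound 3 therefore sits at the limit of > 1000 umol/kg in this assay, at which 2 of the 3 values shown sit, while the remaining reading is the limit of > 320 umol/kg in this assay, at which 1 of the 3 values shown sits. For the measured compounds named here, none of the measured steps has a readable size: a step that the two limits leave unreadable from compound 1 to compound 3, a step that the two limits leave unreadable from compound 1 to compound 2, a step that the two limits leave unreadable from compound 2 to compound 3.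

Compound 4 `CC1CC/C(=N\Nc2ccc(C3CC3)cc2)c2ncc(C(=O)O)c(=O)n21` differs from compound 3 by cyclopropyl in place of ethyl on an aromatic carbon. The two steps that alter the same aromatic carbon are unreadable, so no direction can be anticipated in this assay beyond the scatter; the likeliest result is a further limit. Compound 4 is expected near 1500 umol/kg, within 300 umol/kg to 5000 umol/kg, meaning an expected step that the limit leaves unreadable from compound 3 to compound 4.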

Compound 4, dose for 50% inhibition: 100 umol/kg
Estimate against measurement, compound 4: 15-fold (1.18 log units) above; measured number outside the range, below it.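

In this assay, for the compounds shown here, compound 4 gives 100 umol/kg, the only reading so far that is a number rather than a limit, which shows that the group on the aromatic carbon para to a large group can move this read-out. Cyclopropyl in place of ethyl gives an at least 10-fold lower number from compound 3 to compound 4 (1.00 log units; beyond the scatter), cyclopropyl in place of methyl gives an at least 10-fold lower number from compound 1 to compound 4 (1.00 log units; beyond the scatter), and cyclopropyl in place of nitro gives an at least 3.2-fold lower number from compound 2 to compound 4 (0.50 log units; beyond the scatter), so the series responds to this change in a way that compounds 1, 2 and 3 could not show, since the steps among those three cannot be read. No measured property among the data shown accounts for these steps.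

From the compounds shown here alone, the true size of each step stays open, as compounds 1, 2 and 3 carry only limits and each step is therefore a minimum. Also open, going by these compounds, is whether the three-membered ring itself matters or any larger carbon group on this aromatic carbon would do: isopropyl, cyclobutyl or tert-butyl there would separate the ring from simple branching.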